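Swapping a benzyl for a sulfonyl on a shared indole nitrogen

A few compounds are considered here, and "the series" means these few. Any claim that something is new, unique, unknown or untested is made for them only; others in the source may bear on it.

Compound 1 `C#CCNC1CCc2c(OCCCCN3CCN(c4cccc5c4ccn5Cc4cccc(Cl)c4)CC3)cccc21` carries a 3-chlorobenzyl group on an aromatic nitrogen of its core. In an assay on BTI cells for inhibition of Amine oxidase [flavin-containing] B (Homo sapiens), read by fluorescence, with stated times of 30 min and 1 h (on this read-out lower numbers stand for stronger inhibition and higher numbers for weaker inhibition), compound 1 gives 270 nM. Compound 2 `C#CCNC1CCc2c(OCCCCN3CCN(c4cccc5c4ccn5S(=O)(=O)c4ccccc4)CC3)cccc21` differs from it in one place: phenylsulfonyl in place of 3-chlorobenzyl on an aromatic nitrogen. The measured step is an at least 3.7-fold higher number from compound 1 to compound 2 (0.56 log units; beyond the scatter). For compound 2 the value in this assay is only a limit, > 1000 nM, so the true size of that step is not known; what is known is the limit of > 1000 nM in this assay, at which 2 of the 3 values shown sit.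

Compound 3 `C[C@H](NCc1ccc(OCCCCN2CCN(c3cccc4c3ccn4Cc3cccc(Cl)c3)CC2)cc1)C(N)=O` has a different core from compound 1, and the difference between the two cores is not broken down here. In this assay compound 3 also reaches only a limit, > 1000 nM.

Compound 4 `C[C@H](NCc1ccc(OCCCCN2CCN(c3cccc4c3ccn4S(=O)(=O)c3ccccc3)CC2)cc1)C(N)=O` is related to compound 3 by the same change that turns compound 1 into compound 2: phenylsulfonyl in place of 3-chlorobenzyl on an aromatic nitrogen. The place is described in the same words in both cases, so it is the same change on a different core. The expectation for compound 4 rests on two facts: compound 3 already sits at the limit > 1000 nM, and the same change once gave the step of an at least 3.7-fold higher number from compound 1 to compound 2 (0.56 log units; beyond the scatter). The step that the limit leaves unreadable from compound 3 to compound 4 is therefore expected to be at least as unfavourable as that earlier one. Compound 4 is estimated to give 5000 nM, with a likely range from 1500 nM to 30000 nM, and most probably only a limit will be reported.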

Compound 4, half-maximal inhibitory concentration: > 1000 nM
Compound 4: a limit, no number; the forecaster's own chance of this, stated with the estimate: 90%; the middle value does not contradict the limit.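

Like compound 3, compound 4 reaches only a limit in this assay, > 1000 nM, so the step between these two compounds cannot be read. The compounds shown leave open whether phenylsulfonyl in place of 3-chlorobenzyl on an aromatic nitrogen changes inhibition on the core of compound 3 at all, and how that change would compare in size with the one seen on the core of compound 1.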